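A few compounds are considered here, and "the series" means these few. Any claim that something is new, unique, unknown or untested is made for them only; others in the source may bear on it.

Compound 1 `COc1ccc2[nH]c(C(=O)N3CC(=O)N(Cc4ccccc4)[C@@H](CN4CCCC4)C3)cc2c1`: in a physicochemical assay for solubility, read by spectrophotometry, in phosphate buffer, with a stated time of 2 h, at pH 7.4 (on this read-out higher numbers stand for higher solubility and lower numbers for lower solubility), compound 1 gives > 25000 nM, a limit of the assay rather than a number.
Compound 2 `COc1ccc2[nH]c(C(=O)N3CC(=O)N(Cc4ccccc4)[C@@H](COc4ccc(F)cc4)C3)cc2c1`: in this assay compound 2 gives 17500 nM.
Compound 3 `COc1ccc2[nH]c(C(=O)N3CC(=O)N(Cc4ccccc4)[C@@H](CN4C(=O)c5ccccc5C4=O)C3)cc2c1`: in this assay compound 3 gives > 100000 nM, again a limit and not a number.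

Compound 3 therefore stands only at a limit, (the limit of > 100000 nM in this assay, at which 1 of the 3 values shown sits), and one further value among the three is also a limit, (the limit of > 25000 nM in this assay, at which 1 of the 3 values shown sits). Compound 4 `COc1ccc2[nH]c(C(=O)N3CC(=O)N(Cc4ccccc4)[C@@H](CN4CCC5(CCCC5)CC4)C3)cc2c1` differs from compound 3 by a group of 10 heavy atoms (9 carbon, 1 nitrogen; one five-membered non-aromatic ring of carbon only, one six-membered non-aromatic ring with 1 hetero atom) in place of a group of 11 heavy atoms (8 carbon, 1 nitrogen, 2 oxygen; one five-membered non-aromatic ring with 1 hetero atom, one six-membered aromatic ring of carbon only), on a saturated chain carbon bound to a saturated ring carbon. The measured steps that reach compound 3 are an at least 5.7-fold higher number from compound 2 to compound 3 (0.75 log units; beyond the scatter), whereas a step that the two limits leave unreadable from compound 1 to compound 3. For the measured compounds named here, neither step involves the group that enters in compound 4, and no step joins compound 4 to compound 1; compound 1 and compound 3, each carrying a non-aromatic ring with 1 hetero atom on that chain carbon, both report only limits. The expectation for compound 4 in this assay is thus a high number, plausibly again a limit, with the step of an at least 1.6-fold lower number from compound 3 to compound 4 (0.22 log units; that floor lies within the scatter) expected to stay within the scatter. Compound 4 is estimated at 60000 nM, range 15000 nM to 150000 nM.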

Compound 4, solubility: 5000 nM
Beside the measured number, compound 4's estimate is 12-fold (1.08 log units) above it; the whole stated range lies above it.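

In this assay, a non-aromatic ring with 1 hetero atom on the saturated chain carbon does not by itself keep the number high: the group entering in compound 4 brings a clear fall (an at least 20-fold lower number from compound 3 to compound 4 (1.30 log units; beyond the scatter)) and a second one against the smaller ring of the pyrrolidin-1-yl group (an at least 5.0-fold lower number from compound 1 to compound 4 (0.69 log units; beyond the scatter)). Both of these steps start from limits, so each size is only a floor. The entering group also ends under the 4-fluorophenoxy group (a 3.5-fold lower number from compound 2 to compound 4 (0.54 log units; beyond the scatter)), which makes this the lowest of the four read-outs.

A piperidin-1-yl or morpholin-4-yl group on that chain carbon, without the five-membered ring of carbon only, would show which part of the entering group goes with the fall. The values shown give no cause for these steps.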